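Chain length and acyl-CoA:cholesterol acyltransferase inhibition in carbamate esters

A few compounds are considered here, and "the series" means these few. Any claim that something is new, unique, unknown or untested is made for them only; others in the source may bear on it.

Three compounds sharing one core were measured, and a fourth awaits its number. Compound 1 `CCCCCCCCCCOC(=O)NC(=O)Oc1c(C(C)C)cccc1C(C)C` gives 74 nM in an assay on microsomes from intestine for inhibition of acyl-CoA:cholesterol acyltransferase (Oryctolagus cuniculus); a lower number here means a stronger inhibitor, a higher number a weaker inhibitor. Compound 2 `CCCCCCCCCCCCOC(=O)NC(=O)Oc1c(C(C)C)cccc1C(C)C` gives 21 nM in this assay, and the step of a 3.5-fold lower number from compound 1 to compound 2 (0.55 log units; beyond the scatter) comes from the change (ethyl in place of hydrogen on a saturated chain carbon, ten or more bonds along the chain from an oxygen next to a carbonyl group). Compound 3 `CCCCCCCCCCCCCCCCOC(=O)NC(=O)Oc1c(C(C)C)cccc1C(C)C` gives 50 nM in this assay; it differs from compound 1 by hexyl in place of hydrogen on a saturated chain carbon, ten or more bonds along the chain from an oxygen next to a carbonyl group, which is also how the cores of compound 1 and compound 3 differ, and the step is a 1.5-fold lower number from compound 1 to compound 3 (0.17 log units; within the scatter). Between the two longer-chain compounds the step is a 2.4-fold higher number from compound 2 to compound 3 (0.38 log units; beyond the scatter), so lengthening the chain beyond compound 2 brought the number back up.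

Compound 4 `CCCCCCCCCCCCCCCCCCOC(=O)NC(=O)Oc1c(C(C)C)cccc1C(C)C` has not been measured. It differs from compound 3 by ethyl in place of hydrogen on a saturated chain carbon, ten or more bonds along the chain from an oxygen next to a carbonyl group, the same change that takes compound 1 to compound 2, and the place is described in the same words for both. That earlier change gave the step of a 3.5-fold lower number from compound 1 to compound 2 (0.55 log units; beyond the scatter). Still, the step of a 2.4-fold higher number from compound 2 to compound 3 (0.38 log units; beyond the scatter) shows that once the chain is longer than in compound 2, further growth does not keep lowering the number, and compound 3 already stands with compound 1 within the scatter. The author therefore expects the step from compound 3 to compound 4 in this assay to be a 1.6-fold higher number from compound 3 to compound 4 (0.20 log units; within the scatter), rather than a repeat of the step of a 3.5-fold lower number from compound 1 to compound 2 (0.55 log units; beyond the scatter), because the step of a 2.4-fold higher number from compound 2 to compound 3 (0.38 log units; beyond the scatter) points in the other direction. For compound 4 the estimate is 80 nM, between 30 nM and 220 nM.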

Compound 4, half-maximal inhibitory concentration: 1000 nM
The estimate for compound 4 lay 13-fold (1.10 log units) below the measured number; the whole stated range lies below it.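

In this assay the new steps are a 20-fold higher number from compound 3 to compound 4 (1.30 log units; beyond the scatter), a 48-fold higher number from compound 2 to compound 4 (1.68 log units; beyond the scatter) and a 14-fold higher number from compound 1 to compound 4 (1.13 log units; beyond the scatter), so the longest chain shown gives the highest number of the series. Ethyl in place of hydrogen on a saturated chain carbon therefore does not carry a fixed effect from one core to another: the same change on two cores in this assay, a 3.5-fold lower number (0.55 log units; beyond the scatter) from compound 1 to compound 2 and a 20-fold higher number (1.30 log units; beyond the scatter) from compound 3 to compound 4, 70-fold (1.85 log units) apart, beyond the scatter of two such steps The hexyl change does not carry either: the same change on two cores in this assay, a 1.5-fold lower number (0.17 log units; within the scatter) from compound 1 to compound 3 and a 48-fold higher number (1.68 log units; beyond the scatter) from compound 2 to compound 4, 70-fold (1.85 log units) apart, beyond the scatter of two such steps This shows that in this series the result of adding to the chain depends on the chain already present, but it does not show why, and four compounds do not fix where along the chain the sharp rise begins.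

Still open, on these data alone, is how the number moves for chains of other lengths, which could show whether the rise is gradual or abrupt. Also open, as far as these compounds go, is whether a branched chain, or a chain of similar length ending in a hydroxyl group or a carboxylic acid, would give a number like that of the longest chain here.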